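The compounds below may be only part of what the source reports. "The series", "measured", "known", "first", "only" and "open" are said of these compounds alone.

In a functional assay on HL-60 cells (Homo sapiens) for antiproliferative activity, read by sulforhodamine B assay, with a stated time of 72 h (a higher number here means a weaker inhibitor, a lower number a stronger inhibitor), two compounds sharing one core have been measured: compound 1 (`Cc1cc(C)nc(NS(=O)(=O)c2ccc(Nc3nncc4ccccc34)cc2)n1`) gives 9.5 nM, and compound 2 (`Cc1cc(NS(=O)(=O)c2ccc(Nc3nncc4ccccc34)cc2)no1`) gives 68 nM. Compound 2 therefore holds the higher, weaker number of the pair. Compound 3 (`NS(=O)(=O)c1ccc(Nc2nncc3ccccc23)cc1`) differs from compound 2 by one change, hydrogen in place of 5-methyl-1,2-oxazol-3-yl on a sulfonamide nitrogen. Among the measured compounds shown here, only one measured step bears on this place, a 7.2-fold higher number from compound 1 to compound 2 (0.85 log units; beyond the scatter), a modest step beyond the scatter in which one group replaced another on that same nitrogen. For the measured compounds named here, no measured compound yet carries hydrogen there, so this guide is indirect. Going by that single step, a further rise of modest size is expected, a 2.9-fold higher number from compound 2 to compound 3 (0.47 log units; beyond the scatter). The estimate for compound 3 is 200 nM, with an expected range from 50 nM to 800 nM.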

Compound 3, half-maximal inhibitory concentration: 18 nM
For compound 3 the middle estimate is 11-fold (1.05 log units) above the measured one; the measured number lies below the stated range.
By their numbers in this assay, from the lowest: compounds 1 and 3 (each within the scatter of the next); then compound 2.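

In this assay, among the compounds shown here, the change gives a 3.8-fold lower number from compound 2 to compound 3 (0.58 log units; beyond the scatter) and so runs against the one earlier step on this nitrogen, showing that a low number here does not need a ring group on the sulfonamide nitrogen. With a 1.9-fold higher number from compound 1 to compound 3 (0.28 log units; within the scatter) inside the scatter, hydrogen and 4,6-dimethylpyrimidin-2-yl cannot be told apart at this place, and of the three groups shown, only 5-methyl-1,2-oxazol-3-yl stands apart, with the higher number. Nothing available explains why this group alone raises the number.

The compounds shown leave open whether a small group such as methyl or acetyl on this nitrogen would match hydrogen or follow 5-methyl-1,2-oxazol-3-yl. They also leave open whether an unsubstituted phenyl or pyridyl ring there would behave like 4,6-dimethylpyrimidin-2-yl.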